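Replacing a nitrile with an amide on a fluoroindole chain

A few compounds are considered here, and "the series" means these few. Any claim that something is new, unique, unknown or untested is made for them only; others in the source may bear on it.

Of the compounds shown here, two have been measured so far. Compound 1 `N#CSCCCc1c[nH]c2ccc(F)cc12` gives 23 nM in an assay on isolated protein for inhibition of Myeloperoxidase (Homo sapiens), read by ELISA, with a stated time of 5 min; a higher number here means a weaker inhibitor, a lower number a stronger inhibitor. Among the measured compounds shown here, compound 2 `N#CCCCc1c[nH]c2ccc(F)cc12` gives 72 nM, the highest of the two numbers; the only step measured, a 3.1-fold higher number from compound 1 to compound 2 (0.50 log units; beyond the scatter), swapped one chain end for another. Compound 3 `NC(=O)CCCc1c[nH]c2ccc(F)cc12` differs from compound 2 by carbamoyl in place of cyano on a saturated chain carbon, three bonds along the chain from an aromatic carbon. For the measured compounds named here, no measured step covers this particular swap, so the expectation rests only on the trend that altering this chain end weakened inhibition. Compound 3 is therefore expected to give a weaker result, roughly an 8.3-fold higher number from compound 2 to compound 3 (0.92 log units; beyond the scatter), estimated at 600 nM with a range of 120 nM to 4000 nM.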

Compound 3, half-maximal inhibitory concentration: 18 nM
Compound 3: the middle estimate sits 33-fold (1.52 log units) above what was measured, and the stated range ends above it.
By their numbers in this assay, from the lowest: compounds 3 and 1 (each within the scatter of the next); then compound 2.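

In this assay, the carbamoyl end of compound 3 clearly outperforms the cyano end, with a 4.0-fold lower number from compound 2 to compound 3 (0.60 log units; beyond the scatter). Set against the cyanosulfanyl end, the change gives a 1.3-fold lower number from compound 1 to compound 3 (0.11 log units; within the scatter), so among these compounds the chain end need not carry a cyano unit to reach this level of inhibition. Nothing available here explains this result. As far as these compounds go, whether a carboxylic acid or an amine at this chain end would hold this level remains open. So does the effect of a longer chain carrying the carbamoyl group.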